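Pyridin-3-yl for (Pyridin-2-yl)methyl on the Ring Nitrogen

The source may report more compounds than this note shows. Statements on the series, on what has been measured and on what is new or still open speak of the compounds shown alone.

compound 1 `Nc1ccccc1NC(=O)c1ccc(CSC(=S)N2CCN(Cc3ccccn3)CC2)cc1` — 14.2%
compound 2 `Nc1ccccc1NC(=O)c1ccc(CSC(=S)N2CCc3ccc([N+](=O)[O-])cc32)cc1` — 45.7%

In a functional assay on HeLa cells (Homo sapiens) for antiproliferative activity, read by CCK-8 assay, with a stated time of 72 h, tested at 2 uM (on this read-out higher numbers stand for a stronger effect at the one concentration tested and lower numbers for a weaker effect), compound 1 gives 14.2%, the lowest of the two numbers. Compound 2 gives 45.7% in this assay, a higher number by a margin beyond the scatter. Compound 3 `Nc1ccccc1NC(=O)c1ccc(CSC(=S)N2CCN(c3cccnc3)CC2)cc1` is not yet measured; it differs from compound 1 as follows: pyridin-3-yl in place of (pyridin-2-yl)methyl on an amine nitrogen in a ring. Among the compounds with values here, no measured pair shows this change, so there is no step to lean on. The step of a number 1.8 percentage points higher from compound 1 to compound 3 (within the scatter) is expected to stay within the scatter, in no clear direction. Compound 3 is therefore estimated at 16%, within 4% to 32%.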

Compound 3, a percentage reported as inhibition, at one concentration (the size of the read-out at that concentration, not a potency): 66.2%
For compound 3 the middle estimate is 50.2 percentage points below the measured one; the whole stated range lies below it.
By their numbers in this assay, from the lowest: compound 1; then compound 2; then compound 3.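

In this assay, the group on the amine nitrogen of the six-membered non-aromatic ring proves decisive: pyridin-3-yl in place of (pyridin-2-yl)methyl gives a number 52 percentage points higher from compound 1 to compound 3 (beyond the scatter) on an otherwise unchanged structure. Both groups hold one six-membered aromatic ring with 1 hetero atom and carry no net charge, so those shared counts do not keep the values together. Nothing measured here accounts for the step. The compounds shown do not separate the loss of the methylene link from the shift of the pyridine nitrogen. A directly attached pyridin-2-yl or a phenyl group on this nitrogen would bear on that question.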